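This account rests on a few compounds, and the source may have more. Where it says the series, first, only, none or still open, it means among the compounds named here.

Values in an ADME assay on MRC5 cells (Homo sapiens), read by MTT assay, with a stated time of 72 h; on this read-out lower numbers stand for stronger inhibition and higher numbers for weaker inhibition:
- compound 1 `CNc1ncnc2c1c(-c1ccsc1)cn2[C@@H]1O[C@H](CO)[C@@H](O)[C@H]1O`: > 100000 nM (a limit)
- compound 2 `Cc1nc(N)c2c(-c3ccsc3)cn([C@@H]3O[C@H](CO)[C@@H](O)[C@H]3O)c2n1`: > 100000 nM (a limit)
- compound 3 `Cc1nc(N)c2c(-c3ccccc3)cn([C@@H]3O[C@H](CO)[C@@H](O)[C@H]3O)c2n1`: > 100000 nM (a limit)

Compound 3 has no number to start from, only a limit. It stands with the others at the limit of > 100000 nM in this assay, at which 3 of the 3 values shown sit.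

Compound 4 `Cc1nc(N)c2c(I)cn([C@@H]3O[C@H](CO)[C@@H](O)[C@H]3O)c2n1` carries the change iodo in place of phenyl on an aromatic carbon.

Within the data shown here, the one measured step that bears on this is a step that the two limits leave unreadable from compound 2 to compound 3. Among the measured compounds shown here, it offers no size to carry over, and no iodo compound has been measured in this assay. A readable step is therefore expected only towards stronger inhibition, and of uncertain size, while a result at the same limit remains quite possible.

The expected change is an at least 1.6-fold lower number from compound 3 to compound 4 (0.22 log units; that floor lies within the scatter). For compound 4 the estimated value is 60000 nM, with an expected range of 8000 nM to 100000 nM.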

Compound 4, half-maximal inhibitory concentration: 85800 nM
For compound 4 the middle estimate is 1.4-fold (0.16 log units) below the measured one; the range from low to high includes it.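

In this assay compound 4 gives the first readable number among the compounds shown, 85800 nM, with iodo on the aromatic carbon two ring bonds from the ring nitrogen. Iodo in place of phenyl gives an at least 1.1-fold lower number from compound 3 to compound 4 (0.06 log units; that floor lies within the scatter), and iodo in place of thiophen-3-yl gives an at least 1.1-fold lower number from compound 2 to compound 4 (0.06 log units; that floor lies within the scatter), so neither step is shown to exceed the scatter, although this position can carry a group without a ring and still give a readable value. Compound 4 is the only one off the shared limit: the limit of > 100000 nM in this assay, at which 3 of the 4 values shown sit.

On these data alone, the true size of both steps stays open, as does whether the readable value belongs to iodo itself or to the loss of the aromatic ring. As far as these compounds go, whether bromo, an amine or a short alkyl chain at this carbon would also give a readable value remains unknown.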